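Aryl swap on the benzyl group: what compound 4 may show

The source may report more compounds than this note shows. Statements on the series, on what has been measured and on what is new or still open speak of the compounds shown alone.

Compound 1 `O=c1c2ccccc2c(Nc2n[nH]c3ccccc23)nn1-c1ccccc1`: "not determined" (no result reported) in a functional assay on HCT-116 cells (Homo sapiens) for cytotoxicity, read by CellTiter-Glo, with a stated time of 5 days; on this read-out lower numbers stand for stronger inhibition and higher numbers for weaker inhibition.
Compound 2 `COc1ccc(-n2nc(Nc3cc(C)[nH]n3)c3ccccc3c2=O)cc1`: 700 nM.
Compound 3 `Cc1cc(Nc2nn(Cc3cc(F)ccc3F)c(=O)c3ccccc23)n[nH]1`: 570 nM.
Compound 4 `COc1ccc(Cn2nc(Nc3cc(C)[nH]n3)c3ccccc3c2=O)cc1`: not yet measured.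

Compound 3 and compound 2 stand within the scatter of each other in this assay, so neither can be placed ahead of the other, and compound 1 brings no number to compare. Compound 4 differs from compound 3 in one place: 4-methoxyphenyl in place of 2,5-difluorophenyl on a saturated chain carbon bound to an aromatic nitrogen. Among the measured compounds shown here, the only measured step that bears on this exchange is a 1.2-fold lower number from compound 2 to compound 3 (0.09 log units; within the scatter), which moved the same two aromatic rings in the opposite sense while also adding the chain carbon, and stayed within the scatter. Compound 4 carries the ring of compound 2 on the chain of compound 3, so no step beyond the scatter is expected, a 1.1-fold higher number from compound 3 to compound 4 (0.06 log units; within the scatter). Compound 4 is estimated at 650 nM, within 300 nM to 1500 nM.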

Compound 4, half-maximal inhibitory concentration: 1200 nM
Beside the measured number, compound 4's estimate is 1.8-fold (0.27 log units) below it; measured number inside the range.
By their numbers in this assay, from the lowest: compounds 3, 2 and 4 (each within the scatter of the next, the first and the last beyond it).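

Among the compounds shown here, on the saturated chain carbon bound to an aromatic nitrogen, exchanging 2,5-difluorophenyl for 4-methoxyphenyl gives the first step beyond the scatter in this assay (a 2.1-fold higher number from compound 3 to compound 4 (0.32 log units; beyond the scatter)). With the 4-methoxyphenyl ring kept, inserting the chain carbon stays within the scatter (a 1.7-fold higher number from compound 2 to compound 4 (0.23 log units; within the scatter)), so among these compounds only the change of ring on the chain shows a step beyond it. Nothing available accounts for this difference. The compounds shown leave open whether the step follows the loss of the two fluorines or the arrival of the methoxy group. They also leave open how a single fluorine, a pyridine ring or a longer chain such as 2-phenylethyl would read here.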